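Swapping the Ring-Nitrogen Group of Compound 2

The source may hold more compounds than are shown below. What is called first, only, known or untested is meant among the compounds shown, and "the series" means these compounds.

Values so far in a functional assay on HOS-TE85 cells (Homo sapiens) for inhibition, read by CCK-8 assay, with a stated time of 72 h (on this read-out higher numbers stand for weaker inhibition and lower numbers for stronger inhibition), are these
- compound 1 `COc1ccccc1N1C(=O)CSC1C(=O)NCCCCc1ccccc1` gives > 1000 nM as a limit and not a number
- compound 2 `COc1ccc(F)cc1N1C(=O)CSC1c1cccc(C(=O)NCCCCn2cccn2)c1` gives 97.3 nM as a measured number
- compound 3 `COc1ccc(F)cc1N1C(=O)CSC1c1cccc(C(=O)NCCCCc2ccccc2)c1` gives 8.8 nM as a measured number

Among the compounds with values here, only two of these values are true numbers, and compound 2 holds the higher one at 97.3 nM on this read-out, where a lower number means stronger inhibition. Compound 4 `O=C(NCCCCn1cccn1)c1cccc(C2SCC(=O)N2c2cccc(C3CC3)c2)c1` differs from compound 2 in a single place 3-cyclopropylphenyl in place of 5-fluoro-2-methoxyphenyl on an amide-type nitrogen in a ring and that place is the amide-type nitrogen in a ring.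

Within the data shown here, the one measured step of an 11-fold lower number from compound 2 to compound 3 (1.04 log units; beyond the scatter) is large, but it puts phenyl in place of 1H-pyrazol-1-yl on a saturated chain carbon. That is a different place, so it says little about this change. Among the measured compounds shown here, no measured step alters the group on the ring nitrogen, which leaves both size and direction open. In this assay no step beyond the scatter is therefore expected, and compound 2 at 97.3 nM remains the best anchor. The expected change is a 1.2-fold higher number from compound 2 to compound 4 (0.09 log units; within the scatter) with no firm direction. Compound 4 is estimated at 120 nM with an expected range from 25 nM to 600 nM as the likely span.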

Compound 4, half-maximal inhibitory concentration: 299 nM
The estimate for compound 4 lay 2.5-fold (0.40 log units) below the measured number, within the range that was stated.
By their numbers in this assay, from the lowest: compound 3; then compound 2; then compound 4. At a limit, above all of these: compound 1.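

Within the data shown here, the group on the amide-type nitrogen of the ring turns out to matter in this assay, a point the earlier compounds could not settle: the swap gives a 3.1-fold higher number from compound 2 to compound 4 (0.49 log units; beyond the scatter), so the stronger inhibition of compound 2 is lost in part. Size alone does not describe this change, since both groups have the same count of heavy atoms and both keep a six-membered aromatic ring of carbon only, yet the numbers still move apart. The swap is also a bundled one, as the methoxy group and the fluorine leave together while the cyclopropyl ring enters, so the step belongs to the whole exchange and cannot be assigned to any one of these parts.

Still open, from the compounds shown here alone, is how the pieces contribute on their own, for example with a plain 2-methoxyphenyl group, or how a more different group, such as an aminophenyl or a carboxyphenyl group, would read at this position. Nothing measured here gives a reason for the loss, so the step stands as an observation without an explanation.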